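The source may report more compounds than this note shows. Statements on the series, on what has been measured and on what is new or still open speak of the compounds shown alone.

Measured so far in an ADME assay on microsomes from liver (Mus musculus) for metabolic stability, read by LC-MS, using NADPH, with stated times of 10 min and 30 min, tested at 1 uM; on this read-out lower numbers stand for slow clearance and higher numbers for fast clearance
- compound 1 `COC(=O)C1=C(CN2CCCCC2)NC(c2nccs2)=NC1(C)c1ccc(F)cc1` gives 88 mL/min/kg
- compound 2 `COC(=O)C1=C(CN2CCCS2(=O)=O)NC(c2nccs2)=NC1(C)c1ccc(F)cc1` gives 79 mL/min/kg
- compound 3 `COC(=O)C1=C(CN2CC(OC)C2)NC(c2nccs2)=NC1(C)c1ccc(F)cc1` gives 88 mL/min/kg

Compound 3 stands level with compound 1 and within the scatter of compound 2. The change to compound 4 `COC(=O)C1=C(COC(C(=O)O)C(F)(F)F)NC(c2nccs2)=NC1(C)c1ccc(F)cc1` is a group of 9 heavy atoms (3 carbon, 3 oxygen, 3 fluorine; no ring) in place of a group of 6 heavy atoms (4 carbon, 1 nitrogen, 1 oxygen; one four-membered non-aromatic ring with 1 hetero atom), on a saturated chain carbon bound to a double-bonded ring carbon and it is the only one here that removes the ring. Going by the values given here, three measured steps bear on it: a 1.1-fold lower number from compound 1 to compound 2 (0.05 log units; within the scatter) and no change at the digits printed from compound 1 to compound 3 (within the scatter) and a 1.1-fold higher number from compound 2 to compound 3 (0.05 log units; within the scatter) all lie within the scatter. Each of these swapped one ring group for another, so they guide this change only weakly. A lower number is expected, with low confidence. The expected change is a 2.2-fold lower number from compound 3 to compound 4 (0.34 log units; beyond the scatter) in this assay on this estimate. Compound 4 is estimated at 40 mL/min/kg with an expected range from 12 mL/min/kg to 90 mL/min/kg on this read-out.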

Compound 4, clearance: 24 mL/min/kg
The estimate for compound 4 lay 1.7-fold (0.22 log units) above the measured number; measured number inside the range.
By their numbers in this assay, from the lowest: compound 4; then compounds 2, 1 and 3 (each within the scatter of the next).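

In this assay, going by these compounds alone, the open-chain group on the saturated chain carbon is the only change at this place that goes beyond the scatter, with a 3.7-fold lower number from compound 3 to compound 4 (0.56 log units; beyond the scatter) and a 3.3-fold lower number from compound 2 to compound 4 (0.52 log units; beyond the scatter) and a 3.7-fold lower number from compound 1 to compound 4 (0.56 log units; beyond the scatter). The three ring groups stay within the scatter of one another, so this position does respond to some replacements. Nothing measured here says which feature of the entering group goes with the lower number.

The entering group differs from the ring groups in several features at once, and these remain unseparated. A primary amide in place of its carboxylic acid, or a methyl in place of its trifluoromethyl, would begin to pull them apart.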